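Bromo for hydroxy in a series of limits

The source may hold more compounds than are shown below. What is called first, only, known or untested is meant among the compounds shown, and "the series" means these compounds.

In an ADME assay on HepG2 cells (Homo sapiens) for cytotoxicity, read by CellTiter-Glo and resazurin assay, with a stated time of 72 h (on this read-out lower numbers stand for an effect already at smaller amounts and higher numbers for an effect only at larger amounts of compound), three compounds built on one shared core have so far returned only limits, not numbers. Compound 1 `CC(=O)c1cccc(-c2ccc(C(=O)N(Cc3cccc(OCCCCCC(=O)O)c3)C(C)C)cc2)c1` gives > 26000 nM, which is a limit. Compound 2 `CCOc1cccc(-c2ccc(C(=O)N(Cc3cccc(OCCCCCC(=O)O)c3)C(C)C)cc2)c1` gives > 20800 nM, also a limit. Compound 3 `CC(C)N(Cc1cccc(OCCCCCC(=O)O)c1)C(=O)c1ccc(-c2cccc(O)c2)cc1` gives > 26000 nM, again a limit, so it has no exact place on the scale.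

Compound 4 `CC(C)N(Cc1cccc(OCCCCCC(=O)O)c1)C(=O)c1ccc(-c2cccc(Br)c2)cc1` changes compound 3 in one place: bromo in place of hydroxy on an aromatic carbon, meta to a large group (bromo in place of hydroxy on an aromatic carbon). The closest evidence comes from swaps at that same place, namely a step that the two limits leave unreadable from compound 1 to compound 3 and a step that the two limits leave unreadable from compound 2 to compound 3. Neither gives a size, so no measured change points in any direction. The expected result in this assay is an at least 1.0-fold lower number from compound 3 to compound 4 (0.03 log units; that floor lies within the scatter), with no shift beyond the scatter foreseen. Compound 4 is estimated at 24000 nM, with an expected range from 11000 nM to 40000 nM. Another limit is the likeliest outcome.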

Compound 4, half-maximal effective concentration: > 26000 nM
Compound 4 gave a limit, no number; the forecaster's own chance of this, stated with the estimate: 70%; at least 1.0-fold (0.03 log units) between middle value and limit.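

Among these compounds, compound 4 ends in a limit, just as compound 1, compound 2 and compound 3 do, so no step from any of them to compound 4 can be read in this assay. The compounds shown leave open at what concentration, if any, these four compounds harm the cells.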